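This account rests on a few compounds, and the source may have more. Where it says the series, first, only, none or still open, it means among the compounds named here.

Measured compounds:
- compound 1, `C=Cc1c(CC)nn(CCCN2CCN(c3ccc(C)cc3)CC2)c(=O)c1N`: 28%
- compound 2, `Cc1c(C#N)c(-c2ccccc2)nn1CCCN1CCN(c2cccc(Cl)c2)CC1`: 23%

Both numbers come from a functional assay on the whole organism (Abdomen, strain Swiss) for inhibition, with Mus musculus as the target, with stated times of 30 min, 10 min and 5 min, at a dose of 40 mg/kg by the oral route; a lower number here means a weaker effect, a higher number a stronger effect of the compound at the dose given. Compound 1 gives 28% and compound 2 gives 23%; the two values lie within the usual scatter of each other, so nothing separates them. Within the data shown here, compound 1 and compound 2 differ in more than one place, and no single step between them can be drawn; the pair shows only that two compounds land in the same band of this assay. Among the measured compounds shown here, no step between measured compounds is known at all, so there is no measured guide for any structural change yet.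

The next compound is compound 3, `Cc1c(C#N)c(-c2ccccc2)nn1CCCN1CCN(c2ccc([N+](=O)[O-])cc2)CC1`. It differs from compound 2 in one place: 4-nitrophenyl in place of 3-chlorophenyl on an amine nitrogen in a ring. Nothing measured in the series speaks to an exchange of this kind, so the expected step is none beyond the scatter; the estimated step is a number 2 percentage points higher from compound 2 to compound 3 (within the scatter). For compound 3 the expected value in this assay is therefore 25%, within a range from 10% to 45%.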

Compound 3, a percentage reported as inhibition, in the whole organism at one dose (the size of the read-out at that dose, not a potency): 49%
Compound 3: middle estimate off by 24 percentage points, on the low side; measured number outside the range, above it.
By their numbers in this assay, from the lowest: compounds 2 and 1 (each within the scatter of the next); then compound 3.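

In this assay the exchange of 3-chlorophenyl for 4-nitrophenyl on the amine nitrogen in the ring goes with a number 26 percentage points higher from compound 2 to compound 3 (beyond the scatter) while the rest of the structure stays the same. Among these compounds, this is the first single change that can be read, and it shows that the aryl group on this ring nitrogen is a place where the read-out at this dose can move, which the earlier pair, differing in more than one place, could not show. The step changes the substituent and its place on the phenyl ring together, so it cannot be assigned to either alone, and no measurement at hand bears on why the number moves.

Open, on these data alone, is which of the two changes carries the step: 4-chlorophenyl and 3-nitrophenyl would separate them, and a plain phenyl would give a reference for both. Also open, as far as these compounds go, is whether 4-nitrophenyl brings a similar step on the core of compound 1, and whether the step seen at this single dose reflects a difference in potency.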